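Swapping ethyl for acetoxymethyl on a side chain

A few compounds are considered here, and "the series" means these few. Any claim that something is new, unique, unknown or untested is made for them only; others in the source may bear on it.

Among the measured compounds shown here, measured in a functional assay on MM1 cells (Homo sapiens) for antiproliferative activity, read by MTT assay, with a stated time of 72 h (on this read-out higher numbers stand for weaker inhibition and lower numbers for stronger inhibition), compound 1 `CC[C@H](NC(=O)/C(C#N)=C/c1cccc(Br)n1)c1ccccc1` gives 1100 nM and so holds the lower of the two numbers known so far. Compound 2 `N#C/C(=C\c1ccc(Cl)c([N+](=O)[O-])c1)C(=O)NC(c1ccccc1)C1CC1` stands higher at 2500 nM and that gap lies beyond the usual scatter of repeated measurements. Compound 3 `CC(=O)OC[C@H](NC(=O)/C(C#N)=C/c1cccc(Br)n1)c1ccccc1` keeps the core of compound 1 and alters a single group (acetoxy in place of methyl on a saturated chain carbon, two bonds along the chain from an amide-type nitrogen and an aromatic carbon) with acetoxy in place of methyl on a saturated chain carbon, two bonds along the chain from an amide-type nitrogen and an aromatic carbon. For the measured compounds named here, no measured pair shows what this change does, so any expectation here is uncertain. In this assay a small shift towards weaker inhibition is expected, within the scatter or only just beyond it. The estimated step of a 1.5-fold higher number from compound 1 to compound 3 (0.16 log units; within the scatter) is therefore modest. For compound 3 the expected value is 1600 nM with an estimated range from 550 nM to 4500 nM for a single measurement.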

Compound 3, half-maximal inhibitory concentration: 2600 nM
For compound 3 the middle estimate is 1.6-fold (0.21 log units) below the measured one; the measured number falls inside the stated range.
By their numbers in this assay, from the lowest: compound 1; then compounds 2 and 3 (each within the scatter of the next).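

Among the compounds shown here, this is the first direct reading of this position: on a saturated chain carbon, two bonds along the chain from an amide-type nitrogen and an aromatic carbon, acetoxy in place of methyl gives a 2.4-fold higher number from compound 1 to compound 3 (0.37 log units; beyond the scatter) in this assay. The number at this position therefore responds to the group placed there, and the larger acetoxy group, with its added hydrogen-bond acceptors, still leaves compound 3 with a measurable value of 2600 nM. Nothing available accounts for the direction or size of this step.

As far as these compounds go, it remains open how a hydroxyl group, an amine or a longer chain at this carbon would compare with methyl and acetoxy. A single step also cannot show whether the same swap would act alike on a different core.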